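Caffeate ester amides: morpholinyl against chlorophenyl, cytotoxicity

This account rests on a few compounds, and the source may have more. Where it says the series, first, only, none or still open, it means among the compounds named here.

Compound 1 `COCOc1cc(/C=C/C(=O)OCC(=O)Nc2ccc(Cl)cc2)ccc1OCc1ccccc1` in a functional assay on PC-3 cells (Homo sapiens) for cytotoxicity, read by MTT assay, with a stated time of 72 h (on this read-out lower numbers stand for stronger inhibition and higher numbers for weaker inhibition), gives > 200000 nM, a limit of the assay.
Compound 2 `COCOc1cc(/C=C/C(=O)OCC(=O)NN2CCOCC2)ccc1OCc1ccccc1` in this assay gives > 200000 nM, a limit of the assay.
Compound 3 `O=C(COC(=O)/C=C/c1ccc(O)c(O)c1)NN1CCOCC1` in this assay gives > 200000 nM, a limit of the assay.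

Compound 4 `O=C(COC(=O)/C=C/c1ccc(O)c(O)c1)Nc1ccc(Cl)cc1` is not yet measured. It differs from compound 3 by 4-chlorophenyl in place of morpholin-4-yl on an amide-type nitrogen. The same change is made between compound 2 and compound 1, namely (4-chlorophenyl in place of morpholin-4-yl on an amide-type nitrogen), and there it gave a step that the two limits leave unreadable from compound 2 to compound 1. The difference between the core of compound 3 and the core of compound 2 is not broken down here. Every measured value sits at the limit of > 200000 nM in this assay, at which 3 of the 3 values shown sit, so the measured pair does not show the size of the change. For compound 4 the change is expected to give a number no higher from compound 3 to compound 4 (the limit leaves the size open) because compound 1, compound 2 and compound 3 all sit at the limit of > 200000 nM in this assay, at which 3 of the 3 values shown sit. The estimate for compound 4 in this assay is 200000 nM, most likely reported again only as a limit.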

Compound 4, half-maximal inhibitory concentration: 160000 nM
Compound 4: the middle estimate sits 1.3-fold (0.10 log units) above what was measured, and the stated range covers the measured number.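

In this assay, going by these compounds, 4-chlorophenyl in place of morpholin-4-yl on an amide-type nitrogen gives an at least 1.2-fold lower number from compound 3 to compound 4 (0.09 log units; that floor lies within the scatter), so a measurable value appears on this core, but the true size of the step stays open. The same change on the core of compound 2 cannot be read, so these compounds do not show whether the change carries from one core to the other. Most of the series gives no number to compare: the limit of > 200000 nM in this assay, at which 3 of the 4 values shown sit.

On these data alone, it remains open whether a dimethylamino group or a longer alkyl chain on that nitrogen would give a readable value on either core. A carboxylic acid in place of the ester is equally untested among the compounds shown.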